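Working notes: pyridin-2-yl removal at the sulfonamide nitrogen

The source may hold more compounds than are shown below. What is called first, only, known or untested is meant among the compounds shown, and "the series" means these compounds.

Measured so far:
compound 1, `O=S(=O)(Nc1ccccn1)c1ccc(Nc2nncc3ccccc23)cc1`: 53 nM
compound 2, `C(=C/c1ccccc1)\C(=N\Nc1nncc2ccccc12)c1ccccc1`: 2.2 nM

In a functional assay on MCF7 cells (Homo sapiens) for antiproliferative activity, read by sulforhodamine B assay, with a stated time of 72 h (on this read-out higher numbers stand for weaker inhibition and lower numbers for stronger inhibition), compound 1 gives 53 nM, the higher of the two numbers recorded. Compound 2, a hydrazone without the sulfonamide, gives 2.2 nM in this assay, a gap to compound 1 that lies well beyond the scatter; the two structures differ in more than one place, so the gap is noted and not assigned to any single change.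

Compound 3, `NS(=O)(=O)c1ccc(Nc2nncc3ccccc23)cc1`, is the next entry for this assay. It keeps the core of compound 1 and differs at one position only: hydrogen in place of pyridin-2-yl on a sulfonamide nitrogen. The sulfonamide nitrogen thus carries hydrogen only.

Going by the values given here, no measured pair in this set isolates a change at the sulfonamide nitrogen, so there is no direct precedent for the size of the step. The step of a 1.5-fold higher number from compound 1 to compound 3 (0.18 log units; within the scatter) is expected to be small, on the weaker side, and possibly within the scatter. Compound 3 is therefore estimated at 80 nM in this assay, with a range from 25 nM to 250 nM.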

Compound 3, half-maximal inhibitory concentration: 37 nM
Beside the measured number, compound 3's estimate is 2.2-fold (0.33 log units) above it; the range from low to high includes it.
By their numbers in this assay, from the lowest: compound 2; then compounds 3 and 1 (each within the scatter of the next).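

Going by these compounds alone, the single change of hydrogen in place of pyridin-2-yl on a sulfonamide nitrogen, read in this assay, gives a 1.4-fold lower number from compound 1 to compound 3 (0.16 log units; within the scatter) and is the first step that isolates this position. Within this pair, the whole pyridin-2-yl group, with its 6 heavy atoms and six-membered aromatic ring, can therefore be removed without a change beyond the scatter, and the sulfonamide nitrogen carrying hydrogen only keeps the number in the same range as that of compound 1. No supporting measurement is available to explain why the two compounds read alike.

On these data alone, it remains open whether other groups on this nitrogen, such as methyl, acetyl, phenyl, a longer alkyl chain or a chain ending in an amine or a carboxylic acid, would also stay within the scatter of compound 3 or would move the number in either direction. Compound 2 differs from compound 1 and compound 3 in more than one place, so steps to it cannot be read, and what separates the hydrazone from the sulfonamides remains unresolved.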